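Replacing the Carbamoyl Group: What to Expect for Compound 4

This account rests on a few compounds, and the source may have more. Where it says the series, first, only, none or still open, it means among the compounds named here.

Three close relatives of one shared core have been measured in a functional assay on HEL cells (Homo sapiens); a higher number here means that more compound is tolerated, a lower number that less compound is tolerated. Compound 1 `CCOC(=O)NC(=O)NC1=CS(=O)(=O)O[C@@]12[C@@H](CO[Si](C)(C)C(C)(C)C)O[C@@H](n1cc(C)c(=O)n(C)c1=O)[C@@H]2O[Si](C)(C)C(C)(C)C` gives 14000 nM. Compound 2 `CCOC(=O)CNC(=O)NC1=CS(=O)(=O)O[C@@]12[C@@H](CO[Si](C)(C)C(C)(C)C)O[C@@H](n1cc(C)c(=O)n(C)c1=O)[C@@H]2O[Si](C)(C)C(C)(C)C` gives 13000 nM, and compound 3 `Cc1cn([C@@H]2O[C@H](CO[Si](C)(C)C(C)(C)C)[C@@]3(OS(=O)(=O)C=C3NC(N)=O)[C@H]2O[Si](C)(C)C(C)(C)C)c(=O)n(C)c1=O` gives 11000 nM. Compound 3 sits among these numbers without separating from either of the others: a 1.3-fold lower number from compound 1 to compound 3 (0.10 log units; within the scatter), a 1.2-fold lower number from compound 2 to compound 3 (0.07 log units; within the scatter), and likewise a 1.1-fold lower number from compound 1 to compound 2 (0.03 log units; within the scatter). Compound 4 `Cc1cn([C@@H]2O[C@H](CO[Si](C)(C)C(C)(C)C)[C@@]3(OS(=O)(=O)C=C3NCCC(=O)OCc3ccccc3)[C@H]2O[Si](C)(C)C(C)(C)C)c(=O)n(C)c1=O` differs from compound 3 in one place: 2-(benzyloxycarbonyl)ethyl in place of carbamoyl on an amine nitrogen. Each measured step swapped a group on an amide-type nitrogen and none moved beyond the scatter, but none of them removed the carbamoyl group or introduced 2-(benzyloxycarbonyl)ethyl, so the guidance is loose and no step beyond the scatter is expected. Compound 4 is therefore estimated at 11000 nM, between 4500 nM and 27000 nM, an expected step of no change at the digits printed from compound 3 to compound 4 (within the scatter).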

Compound 4, half-maximal cytotoxic concentration: 200000 nM
For compound 4 the middle estimate is 18-fold (1.26 log units) below the measured one, and the stated range ends below it.
By their numbers in this assay, from the lowest: compounds 3, 2 and 1 (each within the scatter of the next); then compound 4.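

In this assay the amine nitrogen responds strongly, showing an 18-fold higher number from compound 3 to compound 4 (1.26 log units; beyond the scatter) as well as a 15-fold higher number from compound 2 to compound 4 (1.19 log units; beyond the scatter) and a 14-fold higher number from compound 1 to compound 4 (1.15 log units; beyond the scatter) once 2-(benzyloxycarbonyl)ethyl enters. Swaps that kept the carbamoyl carbonyl stayed within the scatter, so this position is not indifferent to every change: removing the carbamoyl group and adding this longer chain means far more compound is tolerated.

Nothing available explains the shift. Going by these compounds, whether the benzyl ester, the chain or the lost carbamoyl carries it stays open, and a carboxylic acid or a plain ethyl group on this nitrogen would help separate these.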